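Removing one hydroxy from compound 3: expected step

The source may report more compounds than this note shows. Statements on the series, on what has been measured and on what is new or still open speak of the compounds shown alone.

compound 1 `O=C(/C=C/c1ccccc1O)CC(=O)/C=C/c1cccc(O)c1O` gives 23000 nM
compound 2 `O=C(/C=C/c1ccc(O)c(O)c1)CC(=O)/C=C/c1cc(O)ccc1O` gives 60000 nM
compound 3 `O=C(/C=C/c1cc(O)ccc1O)CC(=O)/C=C/c1cccc(O)c1O` gives 27000 nM

In a functional assay, with a stated time of 30 min (on this read-out lower numbers stand for stronger inhibition and higher numbers for weaker inhibition), compound 3 sits level with compound 1 and apart from compound 2, so these two compounds share the lower end of this small set.

The step under consideration leads to compound 4 `O=C(/C=C/c1ccccc1O)CC(=O)/C=C/c1cc(O)ccc1O` and turns the 2,3-dihydroxyphenyl into 2-hydroxyphenyl, with hydrogen in place of hydroxy on an aromatic carbon. The carbon concerned is ortho to a hydroxy group.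

Within the data shown here, two measured steps bear on this. The closer one is a 1.2-fold higher number from compound 1 to compound 3 (0.07 log units; within the scatter), also a single exchange between hydrogen and hydroxy on an aromatic carbon, although on the other aromatic ring and in the opposite sense. The other is a 2.2-fold lower number from compound 2 to compound 3 (0.35 log units; beyond the scatter), an exchange of one dihydroxyphenyl for another, and it is modest. Among the measured compounds shown here, the closest precedent stays within the scatter and no measured step is large, so no change beyond the scatter is expected in this assay, and no direction is favoured. The expected step is a 1.1-fold higher number from compound 3 to compound 4 (0.05 log units; within the scatter), though a single precedent supports this only weakly. Compound 4 is estimated at 30000 nM, with an expected range from 14000 nM to 62000 nM.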

Compound 4, half-maximal inhibitory concentration: 48000 nM
For compound 4 the middle estimate is 1.6-fold (0.20 log units) below the measured one; measured number inside the range.
By their numbers in this assay, from the lowest: compounds 1, 3, 4 and 2 (each within the scatter of the next, the first and the last beyond it).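

In this assay, among these compounds, hydrogen in place of hydroxy on the aromatic carbon ortho to a hydroxy group, turning 2,3-dihydroxyphenyl into 2-hydroxyphenyl, gives a 1.8-fold higher number from compound 3 to compound 4 (0.25 log units; within the scatter) and so stays within the scatter; this is the first reading at this position, and it matches the earlier hydrogen and hydroxy exchange on the other ring in staying within the scatter. With 2-hydroxyphenyl held fixed on one side, 2,5-dihydroxyphenyl in place of 2,3-dihydroxyphenyl on the other side gives a 2.1-fold higher number from compound 1 to compound 4 (0.32 log units; beyond the scatter) as a modest step beyond the scatter, so among these compounds the arrangement of the two hydroxy groups on that ring registers where the removal of one hydroxy from compound 3 does not. The step of a 1.3-fold lower number from compound 2 to compound 4 (0.10 log units; within the scatter) for 2-hydroxyphenyl in place of 3,4-dihydroxyphenyl stays within the scatter, so that ring carries one hydroxy or two with no separation here.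

Going by these compounds, whether a methoxy group, an amine or a carboxylic acid on this aromatic carbon would also stay within the scatter remains open. No measurement shown here accounts for any of these steps.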